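Nitro for methoxy on the anilino ring of compound 2

This account rests on a few compounds, and the source may have more. Where it says the series, first, only, none or still open, it means among the compounds named here.

The three measured compounds are all weak in an assay for inhibition of LL-diaminopimelate aminotransferase, chloroplastic (Arabidopsis thaliana); on this read-out lower numbers stand for stronger inhibition and higher numbers for weaker inhibition. Compound 1 `CC(=O)NN1C(=O)/C(=C/c2ccc(-c3ccc([N+](=O)[O-])cc3)o2)SC1=S` gives 73000 nM in this assay, and compound 3 `O=C(N/N=C/c1ccc(O)cc1O)c1[nH]c2ccc([N+](=O)[O-])cc2c1-c1ccccc1` gives 45000 nM in this assay. Compound 2 `CCOC(=O)C1=C(Nc2ccc(OC)cc2)S/C(=C\c2ccc(N(C)C)cc2)C1=O` stands apart from both, as its result is only a limit: in this assay compound 2 gives > 200000 nM, which is the limit of > 200000 nM in this assay, at which 1 of the 3 values shown sits. Compound 2 thus has no number of its own, and nothing places it relative to compound 1 or compound 3 beyond the fact that the other two do return numbers.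

Compound 4 `CCOC(=O)C1=C(Nc2ccc([N+](=O)[O-])cc2)S/C(=C\c2ccc(N(C)C)cc2)C1=O` has not yet been measured in this assay. It differs from compound 2 in one place: nitro in place of methoxy on an aromatic carbon. Among the compounds with values here, no measured pair in this set shows the effect of such a change, so the direction and size of the step are not known from the data; the reader is left with the compound 2 limit and with the unrelated numbers of compound 1 and compound 3.

Compound 4 is expected to remain weak, with an estimated step from compound 2 of an at least 1.3-fold lower number from compound 2 to compound 4 (0.12 log units; that floor lies within the scatter). The estimated value of compound 4 in this assay is 150000 nM, with a range from 50000 nM to 400000 nM.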

Compound 4, half-maximal inhibitory concentration: 141000 nM
Compound 4: middle estimate off by 1.1-fold (0.03 log units), on the high side; the measured number falls inside the stated range.
By their numbers in this assay, from the lowest: compounds 3, 1 and 4 (each within the scatter of the next, the first and the last beyond it). At a limit, above all of these: compound 2.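

In this assay, within the data shown here, the change from 4-methoxyphenyl to 4-nitrophenyl gives the first step that can be read at this position, and it is a bounded one: an at least 1.4-fold lower number from compound 2 to compound 4 (0.15 log units; that floor lies within the scatter). With the nitro group on this aromatic carbon, compound 4 returns a number, 141000 nM, so the shared core now has a measured value to which later changes can be compared. Compound 2 holds only a limit, and the step therefore has a floor but no known size, which leaves the change not shown to lie beyond the scatter: the limit of > 200000 nM in this assay, at which 1 of the 4 values shown sits.

The compounds shown leave open how far the true step extends, and they do not show whether the number of compound 4 reflects something specific to nitro or would also appear with another group in the same place, such as an amine, a carboxylic acid or a chlorine atom. They also leave open whether the dimethylamino group or the ethyl ester on the other parts of compound 4 could be replaced, for example by a hydroxyl group or a carboxylic acid, with any step beyond the scatter.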